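Halogen swap next to the ring nitrogen in compound 2

The compounds below may be only part of what the source reports. "The series", "measured", "known", "first", "only" and "open" are said of these compounds alone.

Measured so far:
compound 1 `Brc1ncccc1OC[C@@H]1CCN1` gives 0.24 nM in an assay on brain for binding affinity to Neuronal acetylcholine receptor; alpha4/beta2 (Rattus norvegicus); a lower number here means a stronger inhibitor, a higher number a weaker inhibitor
compound 2 `Fc1ccc(OC[C@@H]2CCN2)cn1` gives 0.025 nM in this assay

Of the two numbers, compound 2 stands lowest; compound 1 sits a clear distance above it, beyond the scatter, so compound 2 is the stronger binder of the pair. Going by the values given here, the two differ in more than one place, so no single step between them is counted.

Compound 3 `Ic1ccc(OC[C@@H]2CCN2)cn1` is not yet measured. It differs from compound 2 by iodo in place of fluoro on an aromatic carbon. Nothing on hand isolates the effect of this exchange, and compound 1 carries its own halogen on a different pattern, so it gives no direct guide. The expectation is for a small step, if any, and no change beyond the scatter: the estimated step is a 1.6-fold higher number from compound 2 to compound 3 (0.20 log units; within the scatter). Compound 3 is therefore expected to give about 0.04 nM, within 0.012 nM to 0.15 nM.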

Compound 3, inhibition constant: 0.15 nM
Compound 3: the middle estimate sits 3.8-fold (0.57 log units) below what was measured; the measured number falls inside the stated range.
By their numbers in this assay, from the lowest: compound 2; then compounds 3 and 1 (each within the scatter of the next).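

At this place, on an aromatic carbon next to the ring nitrogen, the two halogens are not interchangeable in this assay: iodo in place of fluoro gives a 6.0-fold higher number from compound 2 to compound 3 (0.78 log units; beyond the scatter). Going by these compounds alone, this is the first single-place change that can be read, and it favours fluoro over iodo, although compound 3 still binds strongly at 0.15 nM. Nothing on hand explains the difference between the two halogens.

The compounds shown leave open whether chloro would fall between fluoro and iodo, and whether a non-halogen group such as methyl, a nitrile or an amine could match compound 2 at 0.025 nM. Also open, from the compounds shown here alone, is whether the same exchange would run in the same direction on the core of compound 1, which carries bromo at another place.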